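Replacing the 4-(trifluoromethyl)phenyl group of compound 2

This account rests on a few compounds, and the source may have more. Where it says the series, first, only, none or still open, it means among the compounds named here.

- compound 1 `O=C(CCc1cccc2c1B(O)OC2)Nc1ccccc1`: 200 nM
- compound 2 `O=C(CCc1cccc2c1B(O)OC2)Nc1cccc(-c2ccc(C(F)(F)F)cc2)c1`: 500 nM

In a functional assay on SK-OV-3 cells (Homo sapiens) for antiproliferative activity, read by MTT assay, with a stated time of 72 h (on this read-out higher numbers stand for weaker inhibition and lower numbers for stronger inhibition), compound 2 holds the higher of the two numbers, 500 nM, and is therefore the weaker inhibitor of the pair. Among the measured compounds shown here, only one measured step bears on it: a 2.5-fold higher number from compound 1 to compound 2 (0.40 log units; beyond the scatter), a modest change beyond the scatter, with 4-(trifluoromethyl)phenyl in place of hydrogen on an aromatic carbon.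

The next compound is compound 3 `N#Cc1cccc(-c2cccc(NC(=O)CCc3cccc4c3B(O)OC4)c2)c1`, with 3-cyanophenyl in place of 4-(trifluoromethyl)phenyl on an aromatic carbon, meta to a large group: 3-cyanophenyl in place of 4-(trifluoromethyl)phenyl on an aromatic carbon. The aromatic ring stays, and the group it carries differs. For the measured compounds named here, no measured step replaces one such ring group with another, so the expectation rests on compound 2 at 500 nM and on the modest size of the single known step. In this assay no change beyond the scatter is expected, with only a slight lean toward compound 1 at 200 nM. The expected move is a 1.3-fold lower number from compound 2 to compound 3 (0.10 log units; within the scatter). For compound 3 the estimated value is 400 nM, with an expected range from 150 nM to 1100 nM.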

Compound 3, half-maximal inhibitory concentration: 120 nM
Estimate against measurement, compound 3: 3.3-fold (0.52 log units) above, and the stated range ends above it.
By their numbers in this assay, from the lowest: compounds 3 and 1 (each within the scatter of the next); then compound 2.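

In this assay, the aryl group at this place is not a uniform penalty: 3-cyanophenyl in place of 4-(trifluoromethyl)phenyl gives a 4.2-fold lower number from compound 2 to compound 3 (0.62 log units; beyond the scatter), so the outcome depends on which ring group is carried and not merely on the presence of a second aromatic ring. Set against the unsubstituted anilide, 3-cyanophenyl in place of hydrogen gives a 1.7-fold lower number from compound 1 to compound 3 (0.22 log units; within the scatter), which shows that this aromatic carbon, meta to a large group, can carry a full aryl group without a change beyond the scatter, and that the step up seen for compound 2 is not shared by every aryl group. No measurement on hand accounts for the difference between the two ring groups.

Because these two ring groups differ both in their substituent and in where it sits on the ring, compound 2 and compound 3 cannot separate the nitrile from its placement. From the compounds shown here alone, it also remains open how a plain phenyl ring would read here, or an amine or a carboxylic acid in place of the nitrile.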